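Changing the group on the sulfonyl sulfur of compound 2

This account rests on a few compounds, and the source may have more. Where it says the series, first, only, none or still open, it means among the compounds named here.

Compound 1 `COC(=O)c1cc(=O)c2cc(N)ccc2[nH]1` and compound 2 `COc1ccc(-c2cc(=O)c3c(OC)cc(OC)cc3n2S(=O)(=O)c2ccc(C)c([N+](=O)[O-])c2)cc1` were both tested in a functional assay on HepG2 cells (Homo sapiens) for antiproliferative activity, with a stated time of 72 h; a lower number here means that less compound is needed, a higher number that more compound is needed for the effect. Compound 1 reaches only a limit there, > 33700 nM. Compound 2 likewise gives only a limit in this assay, > 51700 nM. Within the data shown here, no measured step between related compounds exists, so no direction can be read from the data. Compound 3 `COc1ccc(-c2cc(=O)c3c(OC)cc(OC)cc3n2S(=O)(=O)c2ccc(OC)cc2)cc1` is not yet measured; relative to compound 2 the change is 4-methoxyphenyl in place of 4-methyl-3-nitrophenyl on a sulfonyl sulfur. The step is expected to be none beyond the scatter, a step that the limit leaves unreadable from compound 2 to compound 3. Compound 3 is therefore estimated at about 60000 nM, between 20000 nM and 200000 nM, most probably again as a limit.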

Compound 3, half-maximal effective concentration: > 82700 nM
Compound 3 gave a limit, no number; the forecaster's own chance of this, stated with the estimate: 80%; middle value at least 1.3-fold (0.13 log units) away from the limit.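

Among these compounds, compound 2 and compound 3 are both recorded only as limits in this assay, so no step between them can be read. The compounds shown leave open whether 4-methoxyphenyl in place of 4-methyl-3-nitrophenyl on the sulfonyl sulfur changes the antiproliferative effect at all.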